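The compounds below may be only part of what the source reports. "The series", "measured", "known", "first", "only" and "open" are said of these compounds alone.

In an ADME assay on microsomes from liver (Mus musculus) for metabolic stability (a lower number here means that the compound disappears faster, a higher number that the compound lasts longer), compound 3 `CC(C)C(c1ccc(-c2ccc3cccc(F)c3c2)[nH]c1=O)N1CCCCC1=O` gives 0.0967 h. Compound 1 `CC(C)C(Cc1ncc[nH]1)c1ccc(-c2ccc3cccc(F)c3c2)[nH]c1=O` reports only a limit, < 0.0667 h. Compound 2 `CC(C)C(Nc1nnc[nH]1)c1ccc(-c2ccc3cccc(F)c3c2)[nH]c1=O` gives 2.42 h. Compound 3 thus holds the lower of the two actual numbers, and the gap is a 25-fold lower number from compound 2 to compound 3 (1.40 log units; beyond the scatter). Compound 4 `Cc1nc(C(c2ccc(-c3ccc4cccc(F)c4c3)[nH]c2=O)C(C)C)[nH]c1C` carries 4,5-dimethyl-1H-imidazol-2-yl in place of 2-oxopiperidin-1-yl on a saturated chain carbon bound to an aromatic carbon and a saturated chain carbon. For the measured compounds named here, compound 1, with its (1H-imidazol-2-yl)methyl group, is the nearest precedent, and the floor of an at least 1.4-fold higher number from compound 1 to compound 3 (0.16 log units; that floor lies within the scatter) lies within the scatter. The large at least 36-fold higher number from compound 1 to compound 2 (1.55 log units; beyond the scatter) came with the (4H-1,2,4-triazol-3-yl)amino group, which compound 4 lacks. The expected change is therefore none beyond the scatter, an estimated 1.2-fold lower number from compound 3 to compound 4 (0.08 log units; within the scatter). For compound 4 the expected half-life is 0.08 h, within an estimated range of 0.03 h to 0.3 h.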

Compound 4, half-life: 0.0817 h
Compound 4: middle estimate off by 1.0-fold (0.01 log units), on the low side; low and high end bracket the measured number.
By their numbers in this assay, from the lowest: compounds 4 and 3 (each within the scatter of the next); then compound 2. At a limit, below all of these: compound 1.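

In this assay, 4,5-dimethyl-1H-imidazol-2-yl in place of 2-oxopiperidin-1-yl on a saturated chain carbon bound to an aromatic carbon and a saturated chain carbon gives no change beyond the scatter: a 1.2-fold lower number from compound 3 to compound 4 (0.07 log units; within the scatter). An aromatic ring with a hydrogen-bond donor thus enters here with no change beyond the scatter. The gap to the (4H-1,2,4-triazol-3-yl)amino group stays large, with a 30-fold lower number from compound 2 to compound 4 (1.47 log units; beyond the scatter).

From the compounds shown here alone, whether that gap goes with the ring or with its amino link stays open, and a 1H-imidazol-2-ylamino group would separate the two. The comparison with the (1H-imidazol-2-yl)methyl group gives only a floor, an at least 1.2-fold higher number from compound 1 to compound 4 (0.08 log units; that floor lies within the scatter). Compound 1 gives only a limit: the limit of < 0.0667 h in this assay, at which 1 of the 4 values shown sits.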